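A few compounds are considered here, and "the series" means these few. Any claim that something is new, unique, unknown or untested is made for them only; others in the source may bear on it.

Compound 1 `COc1cc(Cl)cc(-c2nn(-c3cccc(NC(=O)Nc4cc(C(F)(F)F)cc(C(F)(F)F)c4)c3)cc2-c2ccncc2)c1` and compound 2 `COc1cc(Cl)cc(-c2nn(-c3cccc(NC(=O)Nc4ccc(Cl)c(Cl)c4)c3)cc2-c2ccncc2)c1` share one core and differ in a single group on an amide-type nitrogen. In a functional assay on ACHN cells (Homo sapiens) for inhibition, read by sulforhodamine B assay, with a stated time of 48 h, tested at 0.01 uM (on this read-out higher numbers stand for a weaker effect at the one concentration tested and lower numbers for a stronger effect), compound 1 gives 103%. In this assay compound 2 gives 102%, which puts it at the low end of the two numbers, though its gap to compound 1 lies within the usual scatter, so the two cannot be told apart. Compound 3 `COc1cc(Cl)cc(-c2nn(-c3cccc(NC(=O)Nc4cccc(C(F)(F)F)c4)c3)cc2-c2ccncc2)c1` has not yet been measured; it differs from compound 2 by 3-(trifluoromethyl)phenyl in place of 3,4-dichlorophenyl on an amide-type nitrogen. Going by the values given here, no measured pair shows this exchange, so no step beyond the scatter is expected in this assay. The step is estimated as a number 1 percentage points lower from compound 2 to compound 3 (within the scatter). Compound 3 is expected to give 101%, within 90% to 112%.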

Compound 3, a percentage reported as activity, at one concentration (the size of the read-out at that concentration, not a potency): 108%
Compound 3: the middle estimate sits 7 percentage points below what was measured; measured number inside the range.
By their numbers in this assay, from the lowest: compounds 2, 1 and 3 (each within the scatter of the next).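

In this assay, the two exchanges on the ring at the amide-type nitrogen stay within the scatter: 3-(trifluoromethyl)phenyl in place of 3,4-dichlorophenyl gives a number 6 percentage points higher from compound 2 to compound 3 (within the scatter), and hydrogen in place of trifluoromethyl on an aromatic carbon gives a number 5 percentage points higher from compound 1 to compound 3 (within the scatter). At the one concentration tested, the three aryl groups at this position therefore cannot be told apart. Nothing at hand bears on this result. Going by these compounds, it remains open whether an amine or a carboxylic acid on this ring would separate from these groups, and whether the three compounds would differ at higher concentrations.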